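The compounds below may be only part of what the source reports. "The series", "measured", "known", "first", "only" and "open" are said of these compounds alone.

Of the compounds shown here, three sharing one core have been tested in an ADME assay on HEK293 cells (Homo sapiens) for cytotoxicity, read by MTT assay, with a stated time of 48 h; a lower number here means a stronger inhibitor, a higher number a weaker inhibitor. Compound 1 `CN(C)CCn1c(N)c(-c2nc3ccccc3[nH]2)c2nc(C#N)c(C#N)nc21` gives 9730 nM, and compound 2 `CCN(CC)CCCn1c(N)c(-c2nc3ccccc3[nH]2)c2nc(C#N)c(C#N)nc21` gives 7870 nM. Compound 3 `CN(C)CCn1c(N)c(-c2nc3cc(Cl)ccc3[nH]2)c2nc(C#N)c(C#N)nc21` gives > 50000 nM, which is a limit of the assay and not a number. Compound 3 therefore stands at the limit of > 50000 nM in this assay, at which 1 of the 3 values shown sits. Its chloro in place of hydrogen on an aromatic carbon accounts for the only difference from the first compound, and that swap gave an at least 5.1-fold higher number from compound 1 to compound 3 (0.71 log units; beyond the scatter).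

Compound 4 `CCN(CC)CCCn1c(N)c(-c2nc3cc(Cl)ccc3[nH]2)c2nc(C#N)c(C#N)nc21` keeps that chloro and changes the side chain, ((diethylamino)methyl in place of dimethylamino on a saturated chain carbon, two bonds along the chain from an aromatic nitrogen). Read a bond further out, 2-(dimethylamino)ethyl becomes 3-(diethylamino)propyl. The same swap has been measured only once, on the compounds without chloro, and it gave a 1.2-fold lower number from compound 1 to compound 2 (0.09 log units; within the scatter). That single step lies within the scatter, so no step beyond the scatter is expected here, and compound 4 may also return only a limit. The expected change is an at least 1.1-fold lower number from compound 3 to compound 4 (0.04 log units; that floor lies within the scatter). Since the starting point is a limit, this estimate is loose. The estimated value for compound 4 is about 45000 nM, with an expected range from 18000 nM to 100000 nM.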

Compound 4, half-maximal inhibitory concentration: 8420 nM
Estimate against measurement, compound 4: 5.3-fold (0.73 log units) above; the measured number lies below the stated range.
By their numbers in this assay, from the lowest: compounds 2, 4 and 1 (each within the scatter of the next). At a limit, above all of these: compound 3.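

In this assay, the swap of 2-(dimethylamino)ethyl for 3-(diethylamino)propyl turns out to depend on what else the molecule carries: with the chloro present it gives an at least 5.9-fold lower number from compound 3 to compound 4 (0.77 log units; beyond the scatter), which does not match the small step seen without the chloro: the same change on two cores in this assay, a 1.2-fold lower number (0.09 log units; within the scatter) from compound 1 to compound 2 and an at least 5.9-fold lower number (0.77 log units; beyond the scatter) from compound 3 to compound 4, at least 4.8-fold (0.68 log units) apart, beyond the scatter of two such steps The chloro shows the same dependence from the other side, for on the 3-(diethylamino)propyl side chain it gives a 1.1-fold higher number from compound 2 to compound 4 (0.03 log units; within the scatter), far from the large step it gave on the 2-(dimethylamino)ethyl side chain: the same change on two cores in this assay, an at least 5.1-fold higher number (0.71 log units; beyond the scatter) from compound 1 to compound 3 and a 1.1-fold higher number (0.03 log units; within the scatter) from compound 2 to compound 4, at least 4.8-fold (0.68 log units) apart, beyond the scatter of two such steps Compound 3 is the only compound at a limit of the assay, so both gaps are minimum sizes and the true ones remain unknown: the limit of > 50000 nM in this assay, at which 1 of the 4 values shown sits.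

The side-chain change lengthens the chain and replaces methyl groups with ethyl groups in a single step, so the compounds shown cannot tell which part matters; a chloro compound carrying a 3-(dimethylamino)propyl or a 2-(diethylamino)ethyl chain would separate the two. Going by these compounds, it also remains open whether a fluoro or a bromo in place of the chloro would depend on the side chain in the same way.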